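A few compounds are considered here, and "the series" means these few. Any claim that something is new, unique, unknown or untested is made for them only; others in the source may bear on it.

Compound 1, `CC(C)CC(C)(O)c1cn(CCNc2nonc2/C(=N/O)Nc2ccc(F)c(Br)c2)nn1`, gives 689 nM in an assay on isolated protein for inhibition of Indoleamine 2,3-dioxygenase 2 (Homo sapiens); a lower number here means a stronger inhibitor, a higher number a weaker inhibitor.
Compound 2, `O/N=C(\Nc1ccc(F)c(Br)c1)c1nonc1NCCn1cc(C2(O)CCCCC2)nn1`, gives 865 nM in this assay.

Within the data shown here, compound 2 carries the highest of the two numbers so far, yet its nearest neighbour is compound 1, and the step of a 1.3-fold higher number from compound 1 to compound 2 (0.10 log units; within the scatter) lies within the scatter, so the two cannot be told apart. That step exchanged one tertiary alcohol on the aromatic carbon of the shared core for another and left the number essentially unchanged.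

Compound 3, `OCCOCc1cn(CCNc2nonc2/C(=N/O)Nc2ccc(F)c(Br)c2)nn1`, is not yet measured. It differs from compound 2 by (2-hydroxyethoxy)methyl in place of 1-hydroxycyclohexyl on an aromatic carbon. Among the measured compounds shown here, no measured step speaks directly to this exchange: the only step available, from compound 1 to compound 2, compares two ring-bearing or branched alcohols of similar size and did not move the number beyond the scatter. On that basis an estimate for compound 3 rests on compound 2 and a small allowance for the smaller, ring-free group; the step of a 1.3-fold higher number from compound 2 to compound 3 (0.10 log units; within the scatter) is expected to be modest. Compound 3 is therefore estimated at 1100 nM, with a range from 400 nM to 3000 nM.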

Compound 3, half-maximal inhibitory concentration: 144 nM
Compound 3: middle estimate off by 7.6-fold (0.88 log units), on the high side, and the stated range ends above it.
By their numbers in this assay, from the lowest: compound 3; then compounds 1 and 2 (each within the scatter of the next).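

In this assay, the group on the aromatic carbon of the five-membered aromatic ring with 3 nitrogen proves able to move the number beyond the scatter, which the exchange between the two earlier tertiary alcohols did not show. The (2-hydroxyethoxy)methyl group stands apart from both of them, with the number falling against 1-hydroxycyclohexyl (a 6.0-fold lower number from compound 2 to compound 3 (0.78 log units; beyond the scatter)) and against 1-hydroxy-1,3-dimethylbutyl (a 4.8-fold lower number from compound 1 to compound 3 (0.68 log units; beyond the scatter)), so the position is not indifferent to what it carries. In this exchange the ring is lost, the heavy-atom count changes and a second oxygen enters all at once, and nothing available accounts for the lower number.

On these data alone, the three compounds do not separate these changes, so it remains open whether the lower number follows the open chain, its ether oxygen or its terminal hydroxyl. A methoxyethoxymethyl group without that hydroxyl, a longer chain of the same kind, or an amine or a carboxylic acid at the chain end would each bear on that question.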